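Hydroxy for chloro on the aryl piperazine

The source may report more compounds than this note shows. Statements on the series, on what has been measured and on what is new or still open speak of the compounds shown alone.

Compound 1 `COCC1=C(C(=O)OC)C(c2cc(F)c(F)cc2F)N(C(=O)NCCCN2CCN(c3ccccc3C(N)=O)CC2)C(=O)N1` and compound 2 `COC(=O)C1=C(C)NC(=O)N(C(=O)NCCCN2CCN(c3ccccc3Cl)CC2)C1c1ccc(F)c(F)c1` share the same core but differ in more than one place, so only their two values are set side by side. In an assay on liver for binding affinity to Alpha-1D adrenergic receptor (Homo sapiens), using microsomes (on this read-out lower numbers stand for stronger inhibition and higher numbers for weaker inhibition), compound 1 gives 190 nM, while compound 2 gives 14 nM, the lowest of the two numbers and well beyond the scatter from compound 1. Compound 3 `COC(=O)C1=C(C)NC(=O)N(C(=O)NCCCN2CCN(c3ccccc3O)CC2)C1c1ccc(F)c(F)c1` carries the change (hydroxy in place of chloro on an aromatic carbon). Among the compounds with values here, with no measured step of this kind, a moderate weakening is expected across the step of a 2.9-fold higher number from compound 2 to compound 3 (0.46 log units; beyond the scatter). Compound 3 is estimated at 40 nM, with a range from 10 nM to 160 nM.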

Compound 3, inhibition constant: 31 nM
Compound 3: the middle estimate sits 1.3-fold (0.11 log units) above what was measured, within the range that was stated.
By their numbers in this assay, from the lowest: compound 2; then compound 3; then compound 1.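

In this assay, within the data shown here, the change from 2-chlorophenyl to 2-hydroxyphenyl gives the first step that can be read at this position: a 2.2-fold higher number from compound 2 to compound 3 (0.35 log units; beyond the scatter). Replacing chloro, with no hydrogen-bond donor or acceptor, by hydroxy, with one of each, therefore weakens the number only modestly, though beyond the scatter. Nothing available explains this step. On these data alone, whether a methoxy group or an amine at this place would read closer to chloro or to hydroxy remains open. So does whether the step would keep its size with other substituents on the shared core.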